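Cytotoxicity check on the shared amide core: fourth aryl group

The compounds below may be only part of what the source reports. "The series", "measured", "known", "first", "only" and "open" are said of these compounds alone.

Compound 3 `O=C(c1ccccc1)c1cccc(NC(=O)C2CCCN(C(=O)c3cc(C(F)(F)F)cc(C(F)(F)F)c3)C2)c1` gives 0% in an ADME assay on PC-3 cells (Homo sapiens) for cytotoxicity, read by WST assay, tested at 100 uM; on this read-out higher numbers stand for more inhibition at the one concentration tested (going by the name of the read-out) and lower numbers for less inhibition. Compound 1 `O=C(Nc1cccc(Oc2ccccn2)c1)C1CCCN(C(=O)c2cc(C(F)(F)F)cc(C(F)(F)F)c2)C1` gives 0% and compound 2 `CC(C)(C)OC(=O)c1cccc(NC(=O)C2CCCN(C(=O)c3cc(C(F)(F)F)cc(C(F)(F)F)c3)C2)c1` gives 0% in this assay; the steps of no change at the digits printed from compound 1 to compound 2 (within the scatter), no change at the digits printed from compound 1 to compound 3 (within the scatter) and no change at the digits printed from compound 2 to compound 3 (within the scatter) show three different groups on the same aromatic carbon leaving the read-out unmoved. Compound 3 thus stands level with compounds 1 and 2. Compound 4 `Cn1cnnc1-c1cccc(NC(=O)C2CCCN(C(=O)c3cc(C(F)(F)F)cc(C(F)(F)F)c3)C2)c1` differs from compound 3 in one place: 4-methyl-4H-1,2,4-triazol-3-yl in place of benzoyl on an aromatic carbon. All three measured steps bear on this exchange, and all were flat. No step beyond the scatter is therefore expected in this assay for compound 4, the expected change being no change at the digits printed from compound 3 to compound 4 (within the scatter). The estimate for compound 4 is 0%, with a range from 0% to 10%.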

Compound 4, a percentage reported as inhibition, at one concentration (the size of the read-out at that concentration, not a potency): 0%
The estimate for compound 4 equals the measured number at the digits printed; the range from low to high includes it.
By their numbers in this assay, from the lowest: compounds 1, 2, 3 and 4 (each within the scatter of the next).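

With the 4-methyl-4H-1,2,4-triazol-3-yl group, a five-membered aromatic ring with 3 hetero atoms sits directly on this aromatic carbon, meta to a large group, and the read-out in this assay stays flat, with no change at the digits printed from compound 3 to compound 4 (within the scatter) and no change at the digits printed from compound 2 to compound 4 (within the scatter) and no change at the digits printed from compound 1 to compound 4 (within the scatter) as the steps. The exchange of benzoyl for this ring also takes the count from 1 hydrogen-bond acceptor to 3 with no effect on the read-out. No evidence on the cause of this flat result is available.

On these data alone, whether any group at this position can move the read-out stays open. A primary amine or a carboxylic acid on this aromatic carbon would test that.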